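Solubility at Low pH: Replacing an Aminothiazole with a Lactam

A few compounds are considered here, and "the series" means these few. Any claim that something is new, unique, unknown or untested is made for them only; others in the source may bear on it.

Compound 1 `CCC(CC)(c1nnc[nH]1)c1ccc(-c2ccc3cccc(F)c3c2)[nH]c1=O`: 28500 nM
Compound 2 `CC(C)C(Nc1nccs1)c1ccc(-c2ccc3cccc(F)c3c2)[nH]c1=O`: 32900 nM

Of the compounds shown here, two sharing the same core have been measured in a physicochemical assay for solubility, measured as kinetic solubility, at pH 2; a lower number here means a less soluble compound, a higher number a more soluble compound. Compound 1 gives 28500 nM in this assay, and compound 2 gives 32900 nM. Compound 2 has the higher of the two numbers, but its nearest neighbour is compound 1, and the gap between them lies within the scatter of the measurement, so the two cannot be told apart.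

Compound 3 `CC(C)C(/C=C1\CCNC1=O)c1ccc(-c2ccc3cccc(F)c3c2)[nH]c1=O` has not been measured. It differs from compound 2 in one place: a group of 7 heavy atoms (5 carbon, 1 nitrogen, 1 oxygen; one five-membered non-aromatic ring with 1 hetero atom) in place of a group of 6 heavy atoms (3 carbon, 2 nitrogen, 1 sulfur; one five-membered aromatic ring with 2 hetero atoms), on a saturated chain carbon bound to an aromatic carbon and a saturated chain carbon. Among the compounds with values here, no measured pair shows a step of this kind, so the size of the step is uncertain. On the two values known, the step from compound 2 to compound 3 is expected to be small and downward, a 1.6-fold lower number from compound 2 to compound 3 (0.22 log units; within the scatter), possibly no larger than the scatter. Compound 3 is therefore estimated at 20000 nM, with a range from 7000 nM to 60000 nM.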

Compound 3, solubility: 23600 nM
Compound 3: the middle estimate sits 1.2-fold (0.07 log units) below what was measured; the range from low to high includes it.
By their numbers in this assay, from the lowest: compounds 3, 1 and 2 (each within the scatter of the next).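

In this assay, putting the five-membered non-aromatic ring in place of the (1,3-thiazol-2-yl)amino group, on a saturated chain carbon bound to an aromatic carbon and a saturated chain carbon, gives a 1.4-fold lower number from compound 2 to compound 3 (0.14 log units; within the scatter), so compound 2 and compound 3 cannot be told apart. At this position, then, the two groups give numbers that cannot be separated, even though they differ in ring type and in hydrogen-bond acceptors, 3 against 1. Nothing measured here speaks to why they read alike.

Still open, going by these compounds, is whether an amine or a carboxylic acid on this same chain carbon would read apart from compound 2 in this assay. Also open, on these data alone, is whether a pyrrolidine ring, with no double bonds outside aromatic rings, would read the same as compound 3.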